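This account rests on a few compounds, and the source may have more. Where it says the series, first, only, none or still open, it means among the compounds named here.

Measured so far in a functional assay on MDA-MB-231 cells (Homo sapiens) for antiproliferative activity, read by MTT assay, with a stated time of 48 h; a lower number here means a stronger inhibitor, a higher number a weaker inhibitor:
- compound 1 `Cc1cnc(Nc2ccc(C(C)C)cc2)nc1Nc1nc2ccccc2s1`: > 50000 nM
- compound 2 `COc1ccc2nc(Nc3nc(Nc4ccc(S(N)(=O)=O)cc4)ncc3C)sc2c1`: > 50000 nM
- compound 3 `COc1ccc2nc(Nc3ccnc(Nc4ccc(S(N)(=O)=O)cc4)n3)sc2c1`: 6240 nM

In this assay the number for compound 1 is a limit of the assay, not a measured value. Compound 2 also sits at that limit, so that the two share (the limit of > 50000 nM in this assay, at which 2 of the 3 values shown sit). Among the measured compounds shown here, compound 3 is the only compound with a number; the step of an at least 8.0-fold lower number from compound 2 to compound 3 (0.90 log units; beyond the scatter) comes with hydrogen in place of methyl on an aromatic carbon of the core and is the sole measured step in the set.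

Compound 4 `Cc1cnc(Nc2ccc(N3CCCCC3)cc2)nc1Nc1nc2ccccc2s1` differs from compound 1 by piperidin-1-yl in place of isopropyl on an aromatic carbon, para to a large group. For the measured compounds named here, no measured step touches that part of the structure: the one step known concerns a methyl on the core, not the para substituent of the aniline. The expectation for compound 4 therefore rests on compound 1 alone, whose value is a limit, and no direction can be read from the data. Compound 4 is estimated to stand at 40000 nM, with a range from 8000 nM to 120000 nM, and the step from compound 1 is expected to be an at least 1.2-fold lower number from compound 1 to compound 4 (0.09 log units; that floor lies within the scatter).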

Compound 4, half-maximal inhibitory concentration: 37200 nM
Compound 4: middle estimate off by 1.1-fold (0.03 log units), on the high side; the measured number falls inside the stated range.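

In this assay, piperidin-1-yl in place of isopropyl on an aromatic carbon, para to a large group, gives an at least 1.3-fold lower number from compound 1 to compound 4 (0.12 log units; that floor lies within the scatter). The floor of that step lies within the scatter and the true size of the step stays unread. Still, compound 4 gives 37200 nM, the first actual number among the compounds shown with methyl on the core. Compound 1 remains a limit of the assay, not a number: the limit of > 50000 nM in this assay, at which 2 of the 4 values shown sit.

Open, from the compounds shown here alone, is whether a morpholin-4-yl group or a carboxylic acid at this place would shift the number further than piperidin-1-yl does. Also open, going by these compounds, is whether hydrogen in place of methyl on the core would act on compound 4 as it did with an at least 8.0-fold lower number from compound 2 to compound 3 (0.90 log units; beyond the scatter).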